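Ethyl for tert-butyl on a long-lived compound

The source may report more compounds than this note shows. Statements on the series, on what has been measured and on what is new or still open speak of the compounds shown alone.

Measured in an ADME assay for pharmacokinetics, read by HPLC (a higher number here means that the compound lasts longer, a lower number that the compound disappears faster), so far:
compound 1 `C/C1=C\[C@@H](O)C(=O)/C=C/C=C/c2csc(n2)[C@@H](C)N2C(=O)C[C@@]([C@@](C)(O)C(=O)SCC(=O)OC(C)(C)C)(CC1)[S+]2[O-]` gives > 24 h
compound 2 `COC1(O[C@@H]2/C=C(\C)CC[C@]3([C@@](C)(O)C(=O)SCc4oc(=O)oc4C)CC(=O)N([C@H](C)c4nc(cs4)/C=C/C=C/C2=O)[S+]3[O-])CCOCC1` gives 18 h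
compound 3 `C/C1=C\[C@@H](O[C@@H]2CCCCO2)C(=O)/C=C/C=C/c2csc(n2)[C@@H](C)N2C(=O)C[C@@]([C@@](C)(O)C(=O)SCc3oc(=O)oc3C)(CC1)[S+]2[O-]` gives 30 h

Compound 1 reads > 24 h as a limit and not a number (the limit of > 24 h in this assay, at which 1 of the 3 values shown sits). Compound 4 (`CCOC(=O)CSC(=O)[C@](C)(O)[C@@]12CC/C(C)=C/[C@@H](O)C(=O)/C=C/C=C/c3csc(n3)[C@@H](C)N(C(=O)C1)[S+]2[O-]`) carries ethyl in place of tert-butyl on an oxygen next to a carbonyl group. Among the compounds with values here, the only measured step is a 1.7-fold higher number from compound 2 to compound 3 (0.22 log units; within the scatter) and it lies within the scatter. That step sits at a different place, on an oxygen on a saturated carbon, so it bears on this change only indirectly. No step beyond the scatter is therefore expected in this assay for this change. The expected step is an at least 1.2-fold lower number from compound 1 to compound 4 (0.07 log units; that floor lies within the scatter) as an estimate. Compound 4 is expected at 20 h with an estimated range (9 h to 40 h).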

Compound 4, half-life: > 24 h
Compound 4: only a limit was reported; the forecaster's own chance of this, stated with the estimate: 30%; middle value at least 1.2-fold (0.07 log units) from the limit.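

In this assay compound 4 gives > 24 h, which is a limit and not a number. Compound 1 reads the same limit, so no step between compound 1 and compound 4 can be read: the limit of > 24 h in this assay, at which 2 of the 4 values shown sit.

The compounds shown leave open whether ethyl in place of tert-butyl changes the half-life at all.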